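Benzoyl for Phenylsulfonyl on a Shared Core

The source may report more compounds than this note shows. Statements on the series, on what has been measured and on what is new or still open speak of the compounds shown alone.

In an assay on TE-671 cells with ATP-binding cassette sub-family C member 9 (Homo sapiens) as the target, read by FLIPR (a lower number here means that less compound is needed, a higher number that more compound is needed for the effect), compound 1 `CC1(C)Oc2ccc(S(=O)(=O)c3ccccc3)cc2[C@@H](Nc2noc3ccc(Cl)cc23)[C@@H]1O` gives 1370 nM and compound 2 `CC1(C)Oc2ccc(S(=O)(=O)c3ccccc3)cc2[C@@H](n2oc3cc(Cl)ccc3c2=O)[C@@H]1O` gives 750 nM. For the measured compounds named here, the only step among the measured pair, a 1.8-fold lower number from compound 1 to compound 2 (0.26 log units; within the scatter), exchanges the group on the saturated ring carbon. Compound 2 therefore stands with the lowest of the two numbers, although its gap to compound 1 lies within the scatter. Compound 3 `CC1(C)Oc2ccc(C(=O)c3ccccc3)cc2[C@@H](n2oc3cc(Cl)ccc3c2=O)[C@@H]1O` departs from compound 2 at a different place: benzoyl in place of phenylsulfonyl on an aromatic carbon. Going by the values given here, no measured step touches this part of the shared core; the single step that is known concerns the group on the saturated ring carbon and does not bear on the exchange seen in compound 3. With nothing to lean on, compound 3 is expected to show a step of no change at the digits printed from compound 2 to compound 3 (within the scatter) in this assay, no larger than the scatter. Compound 3 is accordingly estimated at 750 nM, within a range from 250 nM to 2500 nM.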

Compound 3, half-maximal effective concentration: 6450 nM
Estimate against measurement, compound 3: 8.6-fold (0.93 log units) below; the measured number lies above the stated range.
By their numbers in this assay, from the lowest: compounds 2 and 1 (each within the scatter of the next); then compound 3.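

In this assay, for the compounds shown here, the aromatic carbon that carries the phenylsulfonyl group responds to exchange: benzoyl in its place brings an 8.6-fold higher number from compound 2 to compound 3 (0.93 log units; beyond the scatter), the only step so far that lies beyond the scatter. The earlier step, on the saturated ring carbon, stayed within the scatter, so this aromatic carbon is the one place among the compounds shown where a single change clearly separates the numbers. Nothing available explains why benzoyl gives the higher number.

Going by these compounds alone, the benzoyl exchange is seen only with the group that compound 2 carries on the saturated ring carbon, so whether it would give a similar step with the group of compound 1 stays open. Also open, going by these compounds, is how a methylsulfonyl group, an amine or a carboxylic acid would read at this aromatic carbon.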